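This account rests on a few compounds, and the source may have more. Where it says the series, first, only, none or still open, it means among the compounds named here.

Compound 1, `COc1ccc(-c2cnc(NC(=O)c3ccccc3F)n2C)cc1`, reaches only a limit in a toxicity assay on THP-1 cells (Homo sapiens) for inhibition (on this read-out lower numbers stand for higher toxicity in this test and higher numbers for lower toxicity in this test), > 100000 nM.
Compound 2, `Cc1ccccc1-c1cnc(NC(=O)c2ccc(F)cc2)n1C`, reaches only a limit in this assay, > 50000 nM.
Compound 3, `COc1cccc(-c2cnc(NC(=O)c3ccc(F)cc3)n2C)c1`, reaches only a limit in this assay, > 100000 nM.

Compound 1 therefore stands at the limit of the test rather than at a number, (the limit of > 100000 nM in this assay, at which 2 of the 3 values shown sit), and it shares that position with compound 3. Compound 2 sits at a different limit, (the limit of > 50000 nM in this assay, at which 1 of the 3 values shown sits). Among the compounds with values here, the one step recorded between measured compounds, a step that the two limits leave unreadable from compound 2 to compound 3, cannot be read in size or direction because both ends are limits. Compound 4, `COc1ccc(-c2cnc(NC(=O)C3CCOCC3)n2C)cc1`, differs from compound 1 in one place: oxan-4-yl in place of 2-fluorophenyl on a carbonyl carbon. Within the data shown here, no measured step concerns the group on the carbonyl carbon, so none of the recorded steps bears directly on this change, and the data give no guide to its size. Since every measured compound sits at a limit in this assay, compound 4 is expected to do the same, with the step of a number no higher from compound 1 to compound 4 (the limit leaves the size open) estimated as nothing beyond the scatter. Compound 4 is thus estimated at 100000 nM in this assay, within a range from 40000 nM to 250000 nM, most likely reported again as a limit rather than a number.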

Compound 4, half-maximal cytotoxic concentration: > 100000 nM
Compound 4: only a limit was reported; the forecaster's own chance of this, stated with the estimate: 85%; the middle value lies on the limit itself.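

Compound 4 reaches > 100000 nM in this assay as a limit of the test and not as a number. Compound 1 also stands at a limit, so the step between compound 1 and compound 4 cannot be read. The compounds shown leave open at what concentration any of them becomes toxic to these cells, and whether changing the group on the carbonyl carbon alters that concentration.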